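The source may hold more compounds than are shown below. What is called first, only, known or untested is meant among the compounds shown, and "the series" means these compounds.

Measured so far:
compound 1 `CCCC(=O)N1CCC(CN2CC[C@H](NC(=O)c3cc(Cl)c(N)cc3OC)[C@H](OC)C2)CC1` — 178 nM
compound 2 `COc1cc(N)c(Cl)cc1C(=O)N[C@H]1CCN(CCCn2cncn2)C[C@H]1OC` — 1270 nM

In an assay on COS-7 cells for displacement of a labelled ligand from 5-hydroxytryptamine receptor 4 (Homo sapiens), read by scintillation counting, with a stated time of 30 min (a higher number here means a weaker inhibitor, a lower number a stronger inhibitor), compound 2 gives the highest number of the two; its nearest neighbour is compound 1, with a 7.1-fold higher number from compound 1 to compound 2 (0.85 log units; beyond the scatter). Compound 3 `CCOC(=O)N1CCC(CN2CC[C@H](NC(=O)c3cc(Cl)c(N)cc3OC)[C@H](OC)C2)CC1` is not yet measured. The change is 1-(ethoxycarbonyl)piperidin-4-yl in place of 2-(1H-1,2,4-triazol-1-yl)ethyl on a saturated chain carbon bound to an amine nitrogen in a ring. Going by the values given here, the one step that bears on it is that from compound 1 to compound 2, where a piperidinyl group with an acyl substituent was replaced by the triazolylethyl chain and the number rose modestly. Compound 3 restores a substituted piperidinyl group, so a step of similar size back in the other direction is expected, a 6.4-fold lower number from compound 2 to compound 3 (0.80 log units; beyond the scatter). Compound 3 is thus estimated at 200 nM, range 80 nM to 500 nM.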

Compound 3, half-maximal inhibitory concentration: 377 nM
The estimate for compound 3 lay 1.9-fold (0.28 log units) below the measured number; the range from low to high includes it.
By their numbers in this assay, from the lowest: compound 1; then compound 3; then compound 2.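

In this assay, 1-(ethoxycarbonyl)piperidin-4-yl in place of 2-(1H-1,2,4-triazol-1-yl)ethyl gives a 3.4-fold lower number from compound 2 to compound 3 (0.53 log units; beyond the scatter), so the lower number seen with the piperidinyl group of compound 1 also holds with a second carbonyl substituent. The carbonyl substituent itself matters: ethoxy in place of propyl on the carbonyl carbon gives a 2.1-fold higher number from compound 1 to compound 3 (0.33 log units; beyond the scatter). No measurement here accounts for either step. Still open, going by these compounds, is how a piperidine with a free ring amine would compare, and whether a methoxy or butoxy group on the carbonyl carbon would shift the number further.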